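A few compounds are considered here, and "the series" means these few. Any claim that something is new, unique, unknown or untested is made for them only; others in the source may bear on it.

Measured so far in a functional assay on CHO cells for agonist activity at Alpha-1A adrenergic receptor (Homo sapiens), read by FLIPR and calcium flux; a lower number here means that less compound is needed, a higher number that more compound is needed for the effect:
compound 1 `c1cc(-c2nccs2)c2c(c1)C(c1ncc[nH]1)CC2` gives 426 nM
compound 2 `c1cc(-c2cn[nH]c2)c2c(c1)C(c1ncc[nH]1)CC2` gives 14 nM
compound 3 `Cc1ccc2c(c1NS(C)(=O)=O)CCC2c1ncc[nH]1` gives 33 nM

Compound 2 stands lowest of the three numbers in this assay; compound 3 is nearest to it and compound 1 furthest. Compound 4 `Cn1cc(-c2cccc3c2CCC3c2ncc[nH]2)cn1` is yet to be measured. Relative to compound 2 it carries methyl in place of hydrogen on an aromatic nitrogen. Among the compounds with values here, the only step measured between compounds differing in one place, a 30-fold lower number from compound 1 to compound 2 (1.48 log units; beyond the scatter), exchanges one aromatic ring for another and does not bear on a methyl in place of hydrogen on an aromatic nitrogen. Within the data shown here, no measured pair tests that change, so no step beyond the scatter is expected in either direction, and the range is kept wide. Compound 4 is estimated at 20 nM (range 7 nM to 60 nM), which would mean an expected step of a 1.4-fold higher number from compound 2 to compound 4 (0.15 log units; within the scatter).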

Compound 4, half-maximal effective concentration: > 2900 nM
Compound 4 was reported as a limit (the forecaster's own chance of this, stated with the estimate: 2%); at least 140-fold (2.16 log units) between middle value and limit.
By their numbers in this assay, from the lowest: compound 2; then compound 3; then compound 1. At a limit, above all of these: compound 4.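

In this assay compound 4 stands at a limit of the assay, not at a number: the limit of > 2900 nM in this assay, at which 1 of the 4 values shown sits. The hydrogen on the aromatic nitrogen of the 1H-pyrazol-4-yl group proves no free place for substitution, since methyl there gives an at least 200-fold higher number from compound 2 to compound 4 (2.31 log units; beyond the scatter). With that methyl in place, the ring exchange turns against the earlier step, giving an at least 6.8-fold higher number from compound 1 to compound 4 (0.83 log units; beyond the scatter).

On these data alone, whether any group on that nitrogen gives the same loss stays open. An ethyl, a hydroxyethyl chain or an acetyl there would show whether this holds beyond methyl.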